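This account rests on a few compounds, and the source may have more. Where it says the series, first, only, none or still open, it means among the compounds named here.

In a functional assay on MGC-803 cells (Homo sapiens) for cytotoxicity, read by MTT assay, with a stated time of 48 h (on this read-out higher numbers stand for weaker inhibition and lower numbers for stronger inhibition), compound 1 `CC1=NN(C(=O)CCc2ccccc2)C(c2cc(Br)ccc2O)C1` gives 21200 nM and compound 2 `CC1=NN(C(=O)CN2CCC(Cl)CC2)C(c2ccccc2O)C1` gives 30300 nM; both are weak, and their two values lie within the usual scatter of each other. Compound 3 `O=C(CNC1CC1)N1N=C(c2cc3ccccc3oc2=O)CC1c1ccccc1` is reported in this assay only as "not active" (no number reported), with no number attached, so it stands below anything that could be placed against compounds 1 and 2. Compound 4 `NC(=O)C1CCN(CC(=O)N2N=C(c3cc4ccccc4oc3=O)CC2c2ccccc2)CC1` has not yet been measured and differs from compound 3 in one place: 4-carbamoylpiperidin-1-yl in place of cyclopropylamino on a saturated chain carbon bound to a carbonyl carbon. For the measured compounds named here, no measured step between two compounds shows what this kind of change does here, so any expectation rests on the weak showing of compound 3 alone. Compound 4 is expected to give about 40000 nM in this assay, somewhere between 10000 nM and 150000 nM, if a number is obtained at all.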

Compound 4, half-maximal inhibitory concentration: 21500 nM
Estimate against measurement, compound 4: 1.9-fold (0.27 log units) above, within the range that was stated.
By their numbers in this assay, from the lowest: compounds 1, 4 and 2 (each within the scatter of the next).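

For the compounds shown here, compound 3 has no number in this assay, so no step from it to compound 4 can be read. On these data alone, how far 4-carbamoylpiperidin-1-yl in place of cyclopropylamino shifts cytotoxicity stays open. No available evidence bears on this result.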